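Swapping Isopropyl for Methyl: Solubility Before the Measurement

This account rests on a few compounds, and the source may have more. Where it says the series, first, only, none or still open, it means among the compounds named here.

Three compounds share an amide-linked core with an ether-linked aryl tail, and all three have been tested in a physicochemical assay for solubility, read by nephelometry, in phosphate buffer, at pH 6.5; on this read-out lower numbers stand for lower solubility and higher numbers for higher solubility. In this assay compound 1 `N#Cc1cnc(NC(=O)CCCOc2cccc(Cl)c2)s1` gives < 1600 nM, which is a limit of the assay rather than a number. Compound 2 `Cc1cnc(NC(=O)NCCOc2ccc(Cl)c(C)c2)s1` gives < 1600 nM, again a limit. Compound 3 `CC(C)c1cnc(NC(=O)CCCOc2ccccc2)s1` gives < 1200 nM, also a limit. Compound 3 therefore stands among three compounds for which only limits exist: its own value sits at the limit of < 1200 nM in this assay, at which 1 of the 3 values shown sits, while the other two sit at the limit of < 1600 nM in this assay, at which 2 of the 3 values shown sit. Within the data shown here, no pair of measured compounds differs in just one place, so nothing measured shows how a single change moves this read-out.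

Compound 4 `Cc1cnc(NC(=O)CCCOc2ccccc2)s1` differs from compound 3 in one place: methyl in place of isopropyl on an aromatic carbon. Among the measured compounds shown here, with no measured step to guide it, the expectation rests on the structural change alone. The step of an at least 1.5-fold higher number from compound 3 to compound 4 (0.17 log units; that floor lies within the scatter) is expected to be a modest rise, perhaps just beyond the usual scatter, although the assay may once more return only a limit. Compound 4 is estimated at 1800 nM, with a range from 600 nM to 6000 nM.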

Compound 4, solubility: < 1100 nM
Compound 4 was reported as a limit (the forecaster's own chance of this, stated with the estimate: 55%); at least 1.6-fold (0.21 log units) between middle value and limit.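

In this assay compound 3 and compound 4 are both reported only as limits of the assay, so the step from isopropyl to methyl cannot be read, in either size or direction. The compounds shown leave open what actual number either compound would give, and whether this single change moves the read-out at all.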